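The compounds below may be only part of what the source reports. "The series", "measured", "known", "first", "only" and "open" are said of these compounds alone.

In a functional assay for inhibition, with Homo sapiens as the target (on this read-out higher numbers stand for weaker inhibition and lower numbers for stronger inhibition), compound 1 `C=CCn1ncc2c(C)nc(CC)n2c1=O` sits at the limit of the assay, > 48000 nM. Compound 2 `CCc1nnc(O)n2c(C(C)(C)C)nc(C)c12` gives 26000 nM in this assay. Compound 3 `COCc1nc(Br)c2cnnc(O)n12` likewise reaches only the limit in this assay, > 48000 nM. Compound 3 thus stands at the ceiling of the numbers shown, together with one other value, (the limit of > 48000 nM in this assay, at which 2 of the 3 values shown sit), and no numeric step between measured compounds has been recorded. Compound 4 `CC(C)(C)c1nc(Br)c2cnnc(O)n12` differs from compound 3 by a single change, (tert-butyl in place of methoxymethyl on an aromatic carbon), tert-butyl in place of methoxymethyl on an aromatic carbon. Compound 2 carries a tert-butyl group as well and gives a number rather than a limit in this assay, 26000 nM, though it shares little else with compound 3. The step expected in this assay is an at least 1.3-fold lower number from compound 3 to compound 4 (0.13 log units; that floor lies within the scatter), a move toward stronger inhibition if any, and not clearly beyond the usual scatter. Compound 4 is therefore estimated at 35000 nM, within a range of 15000 nM to 90000 nM, with a fair chance that this assay again reports only a limit.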

Compound 4, half-maximal inhibitory concentration: 19000 nM
Estimate against measurement, compound 4: 1.8-fold (0.27 log units) above; the measured number falls inside the stated range.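

For the compounds shown here, with the step of an at least 2.5-fold lower number from compound 3 to compound 4 (0.40 log units; beyond the scatter), the aromatic carbon between two ring nitrogen atoms proves to be a place where a single change of group moves the read-out in this assay, something no earlier pair could show. On the shared core with its bromo group, tert-butyl brings the series from a limit to a real number, whereas methoxymethyl leaves it at the limit. The size of this step remains a floor only, because the value of compound 3 is a limit and not a number: the limit of > 48000 nM in this assay, at which 2 of the 4 values shown sit.

The compounds shown leave open how much of the change belongs to tert-butyl itself, since a longer chain, a cyclopropyl ring or an amine at this carbon does not appear among them. Whether the same step would hold with something other than the bromo group also stays unanswered.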